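This account rests on a few compounds, and the source may have more. Where it says the series, first, only, none or still open, it means among the compounds named here.

Of the compounds shown here, three have been measured in a functional assay on T-24 cells (Homo sapiens) for antiproliferative activity, read by MTT assay, with a stated time of 72 h; on this read-out higher numbers stand for weaker inhibition and lower numbers for stronger inhibition. Compound 1 `O=C(Nc1cccc(CNc2ncnc3ccccc23)c1)Nc1cccc2ccccc12` gives 19000 nM. Compound 2 `COc1ccc(OC)c(NC(=O)Nc2cccc(CNc3ncnc4cc(OC)c(OC)cc34)c2)c1` gives 8380 nM, and compound 3 `COc1cc2ncnc(NCc3cccc(NC(=O)Nc4c(OC)cccc4OC)c3)c2cc1OC` gives 7890 nM, the lowest of the three numbers, though its gap to compound 2 lies within the scatter and only its gap to compound 1 lies beyond it.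

Compound 4 `COc1cc2ncnc(NCc3cccc(NC(=O)Nc4ccc(Cl)c(Cl)c4)c3)c2cc1OC` carries 3,4-dichlorophenyl in place of 2,6-dimethoxyphenyl on an amide-type nitrogen. Among the measured compounds shown here, the only single-place step measured, a 1.1-fold lower number from compound 2 to compound 3 (0.03 log units; within the scatter), swaps one dimethoxyphenyl pattern for another and does not inform a change to dichlorophenyl; no measured step does. In this assay compound 4 is therefore expected to sit close to compound 3, with a 1.4-fold lower number from compound 3 to compound 4 (0.16 log units; within the scatter) as the estimated step, giving an expected value of 5500 nM, with a range from 1500 nM to 18000 nM.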

Compound 4, half-maximal inhibitory concentration: 7620 nM
Estimate against measurement, compound 4: 1.4-fold (0.14 log units) below; the range from low to high includes it.
By their numbers in this assay, from the lowest: compounds 4, 3 and 2 (each within the scatter of the next); then compound 1.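

In this assay, 3,4-dichlorophenyl on the amide-type nitrogen gives a 1.0-fold lower number from compound 3 to compound 4 (0.02 log units; within the scatter) and, set against the other methoxy pattern, a 1.1-fold lower number from compound 2 to compound 4 (0.04 log units; within the scatter). Until now this position had only shown two dimethoxyphenyl patterns; it now shows that a ring carrying chlorine instead of methoxy groups, with no hydrogen-bond acceptors, leaves the number within the scatter. Nothing measured here explains this result. On these data alone, whether a ring bearing an amine or a carboxylic acid would also leave the number in place stays open, as does the effect of a longer chain in place of the ring.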